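The source may hold more compounds than are shown below. What is called first, only, known or untested is meant among the compounds shown, and "the series" means these compounds.

Compound 1 `CC#CCOC(=O)/C=C(C)/C=C/CC(C)CCCC(C)C` gives 6.4 in a physicochemical assay for lipophilicity (on this read-out lower numbers stand for lower lipophilicity and higher numbers for higher lipophilicity), the lower of the two numbers measured, while compound 2 `CCOC(C)(C)CCCC(C)C/C=C/C(C)=C/C(=O)OC(C)C` gives 6.49 in this assay, a difference that lies within the scatter. Compound 3 `CC(/C=C/CC(C)CCCC(C)C)=C\C(=O)NC(C)C` has not yet been measured in this assay. It differs from compound 1 in one place: isopropylamino in place of (but-2-yn-1-yl)oxy on a carbonyl carbon. For the measured compounds named here, with no measured step of this kind to draw on, a drop beyond the scatter is expected, and the step of a number 1.20 log units lower from compound 1 to compound 3 (beyond the scatter) is the estimate. On that basis compound 3 is expected to give 5.2 in this assay, with a range from 4.6 to 5.8.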

Compound 3, partition coefficient: 5.65
Beside the measured number, compound 3's estimate is 0.45 log units below it; low and high end bracket the measured number.
By their numbers in this assay, from the lowest: compound 3; then compounds 1 and 2 (each within the scatter of the next).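

In this assay, the carbonyl carbon now has its first measured one-place step: isopropylamino in place of (but-2-yn-1-yl)oxy gives a number 0.75 log units lower from compound 1 to compound 3 (beyond the scatter), and this lies beyond the scatter. For the compounds shown here, compound 1 and compound 2 offered no such step, so this position could not be read before. Nothing measured here accounts for the size of this step. From the compounds shown here alone, it remains open how a carboxylic acid or a dimethylamino group on the same carbonyl carbon would compare with isopropylamino, and whether the same exchange would give a similar step on compound 2.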